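Aryl substituent exchange on the shared core

The compounds below may be only part of what the source reports. "The series", "measured", "known", "first", "only" and "open" are said of these compounds alone.

The shared core carries an aryl substituent on an aromatic carbon, and two compounds have been measured in a functional assay on AGS cells (Homo sapiens) for cytotoxicity, read by MTT assay, with a stated time of 48 h; on this read-out higher numbers stand for weaker inhibition and lower numbers for stronger inhibition. Compound 1 `COc1ccc(-c2c3ccc4ccccc4c3nc3c2c(C)nc2c4ccccc4ccc32)cc1` gives 66400 nM in this assay. Compound 2 `Cc1ccc(-c2c3ccc4ccccc4c3nc3c2c(C)nc2c4ccccc4ccc32)cc1` reaches only the limit of this assay, > 80000 nM. Going by the values given here, the single measured step, an at least 1.2-fold higher number from compound 1 to compound 2 (0.08 log units; that floor lies within the scatter), rests on the limit of > 80000 nM in this assay, at which 1 of the 2 values shown sits, and resolves no change beyond the scatter. Compound 2 thus stands at the limit of this assay, with a range rather than a number.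

Compound 3 `Cc1nc2c3ccccc3ccc2c2nc3c(ccc4ccccc43)c(-c3cc(O)nc4ccccc34)c12` is the next step: 2-hydroxyquinolin-4-yl in place of 4-methylphenyl on an aromatic carbon. Among the compounds with values here, the one measured step concerns methyl against methoxy and does not touch a change of this kind, so no measured step bears on it directly. Compound 3 is expected to stay in the region of the numbers shown, estimated at 60000 nM with a range of 20000 nM to 150000 nM. The expected step is an at least 1.3-fold lower number from compound 2 to compound 3 (0.12 log units; that floor lies within the scatter), with no direction beyond the scatter that the data support; a limit rather than a number remains a real possibility.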

Compound 3, half-maximal inhibitory concentration: 15800 nM
For compound 3 the middle estimate is 3.8-fold (0.58 log units) above the measured one; the whole stated range lies above it.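

On the aromatic carbon opposite the ring nitrogen, 2-hydroxyquinolin-4-yl gives the first differences in this assay that lie beyond the scatter, with an at least 5.0-fold lower number from compound 2 to compound 3 (0.70 log units; beyond the scatter) against 4-methylphenyl and a 4.2-fold lower number from compound 1 to compound 3 (0.62 log units; beyond the scatter) against 4-methoxyphenyl. This position therefore responds to the group it carries, which the exchange of methyl for methoxy on the phenyl ring could not show. The entering group differs from 4-methylphenyl at once in its second aromatic ring, its ring nitrogen, and its hydrogen-bond donor and acceptors, so the step cannot be assigned to any one of these, and the step from compound 2 gives only a floor: the limit of > 80000 nM in this assay, at which 1 of the 3 values shown sits.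

On these data alone, whether the hydroxy group or the added ring carries the difference stays open, and plain quinolin-4-yl or a phenyl ring bearing an amine at this carbon would help to separate the two. Also open, as far as these compounds go, is whether the methyl group elsewhere on the shared core matters, for instance if a longer chain or a carboxylic acid stood in its place.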